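A few compounds are considered here, and "the series" means these few. Any claim that something is new, unique, unknown or untested is made for them only; others in the source may bear on it.

Three compounds from one series have been examined in an ADME assay on HepG2 cells (Homo sapiens) for cytotoxicity, read by MTT assay; a lower number here means a stronger inhibitor, a higher number a weaker inhibitor. Compound 1 `O=C(Nc1ccccc1)Oc1ccc(Cl)cc1C(=O)Nc1ccc(F)cc1` serves as the reference point. In this assay compound 1 reaches only a limit, > 20000 nM. Compound 2 `O=C(NC1CCCCC1)Oc1ccc(Cl)cc1C(=O)Nc1ccc(F)cc1` differs from compound 1 by cyclohexyl in place of phenyl on an amide-type nitrogen. In this assay compound 2 gives 21200 nM. The step that the limit leaves unreadable from compound 1 to compound 2 cannot be sized, since the limit of > 20000 nM in this assay, at which 1 of the 3 values shown sits, caps the first value. Compound 3 `O=C(Nc1ccccc1)Oc1ccc(Cl)cc1C(=O)Nc1ccc(Cl)cc1` carries a different core from compound 1, the difference being (chloro in place of fluoro on an aromatic carbon). In this assay compound 3 also stops at a limit, > 250000 nM. The step that the two limits leave unreadable from compound 1 to compound 3 is likewise not readable, as both ends rest on limits, the limit of > 20000 nM in this assay, at which 1 of the 3 values shown sits, and (the limit of > 250000 nM in this assay, at which 1 of the 3 values shown sits).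

Compound 4 `O=C(NC1CCCCC1)Oc1ccc(Cl)cc1C(=O)Nc1ccc(Cl)cc1` has not yet been measured. It stands to compound 3 as compound 2 stands to compound 1: cyclohexyl in place of phenyl on an amide-type nitrogen, the same change at the same place. In this assay the step is expected to be an at least 1.6-fold lower number from compound 3 to compound 4 (0.22 log units; that floor lies within the scatter), an expectation resting on the earlier step that the limit leaves unreadable from compound 1 to compound 2, which left compound 2 at a value of much the same order as the limit reached by compound 1. Compound 4 is therefore estimated at 150000 nM, with a likely range from 40000 nM to 300000 nM.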

Compound 4, half-maximal inhibitory concentration: > 250000 nM
Compound 4: no number, only a limit (the forecaster's own chance of this, stated with the estimate: 60%); at least 1.6-fold (0.22 log units) between middle value and limit.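

In this assay compound 4 stops at a limit, > 250000 nM. The step from phenyl to cyclohexyl on the amide-type nitrogen cannot be read on either core, so the compounds shown do not tell whether this change carries from the core of compound 1 to the core of compound 3, in size or in direction: the limit of > 250000 nM in this assay, at which 2 of the 4 values shown sit. The one step that can be read is a different change, chloro in place of fluoro on an aromatic carbon with cyclohexyl on the nitrogen, and it is an at least 11-fold higher number from compound 2 to compound 4 (1.07 log units; beyond the scatter); it gives only a floor, and it rests on this single pair.

The compounds shown leave open how far apart compound 3 and compound 4 really lie, since neither has a number. They also leave open what a bromo group on that aromatic carbon, or a benzyl group or a longer alkyl chain on the amide-type nitrogen, would give in this assay.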